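The compounds below may be only part of what the source reports. "The series", "measured", "known", "first", "only" and "open" are said of these compounds alone.

Compound 2 `CCNC(=O)c1cc(N)c(Nc2ccc(C#N)cc2)cc1Oc1c(C)cc(/C=C/C#N)cc1C` holds the highest number of the three compounds measured in a physicochemical assay for solubility, read by HPLC, with a stated time of 4 h, at pH 2; a lower number here means a less soluble compound, a higher number a more soluble compound. In this assay compound 2 gives 69.4 ug/mL. Compound 1 `Cc1cc(/C=C/C#N)cc(C)c1Oc1cc(Nc2ccc(C#N)cc2)c(N)cc1C(=O)OCCC#N` sits furthest from it, and in this assay compound 1 gives 0.94 ug/mL; compound 3 `Cc1cc(/C=C/C#N)cc(C)c1Oc1cc(Nc2ccc(C#N)cc2)c(N)cc1C(=O)NCCCO` is the nearest, and in this assay compound 3 gives 19.9 ug/mL. The steps behind these numbers are a 74-fold higher number from compound 1 to compound 2 (1.87 log units; beyond the scatter), a 21-fold higher number from compound 1 to compound 3 (1.33 log units; beyond the scatter) and a 3.5-fold lower number from compound 2 to compound 3 (0.54 log units; beyond the scatter).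

Compound 4 `Cc1cc(/C=C/C#N)cc(C)c1Oc1cc(Nc2ccc(C#N)cc2)c(N)cc1C(N)=O` differs from compound 2 in one place: hydrogen in place of ethyl on an amide-type nitrogen. Among the measured compounds shown here, no measured step removes the ethyl from this amide-type nitrogen. The large steps from compound 1 concern a carbonyl carbon exchanging an ester-type group for an amide-type one, and the modest step from compound 2 to compound 3 concerns a chain grown rather than shortened. These steps bear only loosely on the present change, so the expected step in this assay is small, most likely within the scatter, with a slight lean upward.

Compound 4 is therefore expected to give 90 ug/mL in this assay, within a range of 30 ug/mL to 250 ug/mL, which means an expected step of a 1.3-fold higher number from compound 2 to compound 4 (0.11 log units; within the scatter).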

Compound 4, solubility: 2.09 ug/mL
Compound 4: the middle estimate sits 43-fold (1.63 log units) above what was measured, outside the stated range (below it).
By their numbers in this assay, from the lowest: compound 1; then compound 4; then compound 3; then compound 2.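

In this assay the group on this amide-type nitrogen proves to matter a great deal: hydrogen in place of ethyl gives a 33-fold lower number from compound 2 to compound 4 (1.52 log units; beyond the scatter) and hydrogen in place of 3-hydroxypropyl gives a 9.5-fold lower number from compound 3 to compound 4 (0.98 log units; beyond the scatter) in the same direction. The earlier steps from compound 1 had shown only a carbonyl carbon exchanging 2-cyanoethoxy for a substituted amino group, whereas amino in place of 2-cyanoethoxy gives a 2.2-fold higher number from compound 1 to compound 4 (0.35 log units; beyond the scatter) and so leaves most of the distance to compound 2 and compound 3 to the chain on the nitrogen. Among the compounds shown here, nothing given here bears on why removing the ethyl lowers the number so far.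

The compounds shown leave open how the number changes with a methyl, a propyl or a longer chain on this nitrogen, and so whether ethyl stands near a peak or on a continuing rise. They also leave open whether a chain ending in an amine or a carboxylic acid would stand with compound 3 and compound 2 or nearer compound 4 in this assay on this same amide-type nitrogen.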